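Bromomethyl in place of diacetoxymethyl on the shared core

A few compounds are considered here, and "the series" means these few. Any claim that something is new, unique, unknown or untested is made for them only; others in the source may bear on it.

In an ADME assay on L929 cells (Mus musculus) for antiproliferative activity, read by WST assay, with a stated time of 5 days (on this read-out higher numbers stand for weaker inhibition and lower numbers for stronger inhibition), compound 1 (`COc1cc(O)c2c(c1O)C/C(C)=C\CC[C@@]1(C)O[C@@H]1C2=O`) gives 9700 nM, compound 2 (`COc1cc(O)c2c(c1O)C/C(CO)=C\CC[C@@]1(C)O[C@@H]1C2=O`) gives 40000 nM and compound 3 (`COc1cc(O)c2c(c1O)C/C(C(OC(C)=O)OC(C)=O)=C\CC[C@@]1(C)O[C@@H]1C2=O`) gives 2700 nM, the lowest of the three numbers.

Compound 4 (`COc1cc(O)c2c(c1O)C/C(CBr)=C\CC[C@@]1(C)O[C@@H]1C2=O`) carries bromomethyl in place of diacetoxymethyl on a double-bonded ring carbon. For the measured compounds named here, no measured compound carries bromomethyl, so the evidence is indirect and comes only from the other groups at this carbon. The modest 4.1-fold higher number from compound 1 to compound 2 (0.62 log units; beyond the scatter) and the modest 3.6-fold lower number from compound 1 to compound 3 (0.56 log units; beyond the scatter) both lie beyond the scatter, as does the large 15-fold lower number from compound 2 to compound 3 (1.17 log units; beyond the scatter). Compound 3 sits at the low end of this small set, so a modest move to a higher number is expected in this assay, with a step as large as a 15-fold lower number from compound 2 to compound 3 (1.17 log units; beyond the scatter) not expected. The expected step is a 2.2-fold higher number from compound 3 to compound 4 (0.35 log units; beyond the scatter). For compound 4, the estimated value is 6000 nM, with an expected range of 1500 nM to 22000 nM.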

Compound 4, half-maximal inhibitory concentration: 10000 nM
Estimate against measurement, compound 4: 1.7-fold (0.22 log units) below, and the stated range covers the measured number.
By their numbers in this assay, from the lowest: compound 3; then compounds 1 and 4 (each within the scatter of the next); then compound 2.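

In this assay, bromomethyl on this double-bonded ring carbon does not keep the low number seen with diacetoxymethyl (a 3.7-fold higher number from compound 3 to compound 4 (0.57 log units; beyond the scatter)), but it also stays clear of the hydroxymethyl result (a 4.0-fold lower number from compound 2 to compound 4 (0.60 log units; beyond the scatter)). Bromo in place of hydrogen on the saturated chain carbon gives no readable change (a 1.0-fold higher number from compound 1 to compound 4 (0.01 log units; within the scatter)), so among these four groups only diacetoxymethyl and hydroxymethyl separate from methyl, and they do so in opposite directions. No measured evidence accompanies these compounds that could explain the differences.

From the compounds shown here alone, whether the low number of compound 3 needs both acetoxy units of diacetoxymethyl or would survive with a single acetoxymethyl group remains open. Also open, going by these compounds, is how an aminomethyl group or a carboxylic acid would read on this carbon.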